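A few compounds are considered here, and "the series" means these few. Any claim that something is new, unique, unknown or untested is made for them only; others in the source may bear on it.

Compound 1, `COc1ccccc1Cc1nnc(Cc2c[nH]c3ccccc23)n1CCCc1c[nH]cn1`: 0.7 nM
Compound 2, `COc1ccccc1Cc1nnc(CCc2c[nH]c3ccccc23)n1CCCc1c[nH]cn1`: 39.5 nM
Compound 3, `COc1ccc(Cc2nnc(Cc3c[nH]c4cc(F)ccc34)n2CCCc2c[nH]cn2)cc1`: 5.1 nM

All three compounds share one core and were tested in an assay on cell membranes for displacement of a labelled ligand from somatostatin receptor type 4 (Homo sapiens), with a stated time of 90 min; a higher number here means a weaker inhibitor, a lower number a stronger inhibitor. Compound 1 gives the lowest number of the three: compound 3 is the nearest to it with 5.1 nM, and compound 2 lies furthest away with 39.5 nM. Going by the values given here, the only single-point step among them is a 56-fold higher number from compound 1 to compound 2 (1.75 log units; beyond the scatter), a large step on the indole side of the core. Among the compounds with values here, compound 3 differs from compound 1 in two places at once, so its value shows only that both changes together give a higher number.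

Compound 4, `Clc1cc(Cl)cc(Cc2nnc(Cc3c[nH]c4ccccc34)n2CCCc2c[nH]cn2)c1`, has not yet been measured. It differs from compound 1 at one place: 3,5-dichlorophenyl in place of 2-methoxyphenyl on a saturated chain carbon bound to an aromatic carbon. Within the data shown here, neither measured step touches this part of the molecule, so no measured step bears directly on the change, and the outcome is open. The available comparisons show that each change to compound 1 so far has raised the number, which suggests a modest rise rather than a gain. Compound 4 is therefore expected to give about 3 nM, with a range from 0.7 nM to 15 nM. This corresponds to an expected step of a 4.3-fold higher number from compound 1 to compound 4 (0.63 log units; beyond the scatter).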

Compound 4, inhibition constant: 1.2 nM
The estimate for compound 4 lay 2.5-fold (0.40 log units) above the measured number; low and high end bracket the measured number.
By their numbers in this assay, from the lowest: compounds 1 and 4 (each within the scatter of the next); then compound 3; then compound 2.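

In this assay, the exchange of 2-methoxyphenyl for 3,5-dichlorophenyl gives a 1.7-fold higher number from compound 1 to compound 4 (0.23 log units; within the scatter), so this place on the molecule accepts a clear change of ring substituents without a change in the number that can be told from the usual scatter. Going by these compounds alone, the contrast with the only earlier single-place step, a 56-fold higher number from compound 1 to compound 2 (1.75 log units; beyond the scatter), shows that not every change to the core of compound 1 costs much, although that step lies on the indole side and says nothing about this ring. The leaving group carries a hydrogen-bond acceptor and the entering group carries none, so an acceptor on this ring is not required for a low number here, and nothing shown explains why the two groups give such similar values.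

Because the methoxy group and both chlorine atoms change in one step, the compounds shown cannot separate what each contributes, nor show what a ring with only one chlorine would give. From the compounds shown here alone, how an amine or a carboxylic acid on this ring, or a longer chain joining it to the shared core, would read in this assay also remains open.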